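A Trifluoromethyl Step Taken From Two Limits

The source may hold more compounds than are shown below. What is called first, only, known or untested is meant among the compounds shown, and "the series" means these compounds.

Measured compounds:
Compound 1 `CC(C)n1ncc2c(C(=O)NCc3cn(-c4ccccc4)nn3)cccc21` gives > 40000 nM in a functional assay on HepG2 cells (Homo sapiens) for inhibition, read by MTT assay, with a stated time of 72 h (on this read-out higher numbers stand for weaker inhibition and lower numbers for stronger inhibition), a limit of the assay and not a number.
Compound 2 `CC(C)n1ncc2c(C(=O)NCc3cn(-c4ccc(F)cc4)nn3)cccc21` gives > 40000 nM in this assay, again a limit and not a number.

Compound 1 therefore stands only at the edge of what this assay reports, and compound 2 sits at that same edge (the limit of > 40000 nM in this assay, at which 2 of the 2 values shown sit). Going by the values given here, the one measured step, a step that the two limits leave unreadable from compound 1 to compound 2, is consequently unreadable: both ends are limits, so its size cannot be told. Compound 3 `CC(C)n1ncc2c(C(=O)NCc3cn(-c4ccc(C(F)(F)F)cc4)nn3)cccc21` differs from compound 1 by trifluoromethyl in place of hydrogen on an aromatic carbon. Among the compounds with values here, no measured step bears on this change, and nothing in the two values shown points either up or down. Compound 3 is expected to remain at or near the same edge, and is estimated at 40000 nM, with a range of 10000 nM to 120000 nM. The expected step is a number no higher from compound 1 to compound 3 (the limit leaves the size open), which amounts to no change beyond the scatter.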

Compound 3, half-maximal inhibitory concentration: > 40000 nM
Compound 3 was reported as a limit; the forecaster's own chance of this, stated with the estimate: 75%; the middle value sits exactly at the limit.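

No step among compound 1, compound 2 and compound 3 can be read, because all three stop at the same limit of this assay, which is not a number: the limit of > 40000 nM in this assay, at which 3 of the 3 values shown sit.

Left open is how strongly each compound inhibits, and whether fluoro or trifluoromethyl in place of hydrogen changes that at all.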